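The compounds below may be only part of what the source reports. "The series", "measured", "known", "first", "only" and "open" are said of these compounds alone.

Of the compounds shown here, three built on a shared core have been measured in an ADME assay on the whole organism (plasma) for pharmacokinetics, with Rattus norvegicus as the target, at a dose of 10 mg/kg by the oral route; on this read-out lower numbers stand for lower exposure and higher numbers for higher exposure at the dose given. Compound 1 `C=CCNC(=O)C(=O)C(CCC)NC(=O)[C@@H]1[C@@H]2[C@H](CN1C(=O)[C@@H](NC(=O)N[C@@H](CN1CCCCC1=O)C(C)(C)C)C1CCCCC1)C2(C)C` gives 479 ng.h/mL. Compound 2 `C#CCCC(NC(=O)[C@@H]1[C@@H]2[C@H](CN1C(=O)[C@@H](NC(=O)N[C@@H](CN1CCC(C)(C)CC1=O)C(C)(C)C)C(C)(C)C)C2(C)C)C(=O)C(=O)NCC=C` gives 342 ng.h/mL. Compound 3 `C=CCNC(=O)C(=O)C(CCC)NC(=O)[C@@H]1[C@@H]2[C@H](CN1C(=O)[C@@H](NC(=O)N[C@@H](CN1CCCNC1=O)C(C)(C)C)C(C)(C)C)C2(C)C` gives 46.2 ng.h/mL. Among these three numbers compound 2 holds the second highest: the number for compound 1 lies within the usual scatter of it, so nothing separates those two, while compound 3 sits beyond the scatter below it. Compound 4 `C=CCNC(=O)C(=O)C(CC1CCC1)NC(=O)[C@@H]1[C@@H]2[C@H](CN1C(=O)[C@@H](NC(=O)N[C@@H](CN1CCC(C)(C)CC1=O)C(C)(C)C)C(C)(C)C)C2(C)C` has not yet been measured in this assay. It differs from compound 2 in one place: cyclobutyl in place of propargyl on a saturated chain carbon, two bonds along the chain from an amide-type nitrogen and a carbonyl carbon. For the measured compounds named here, no measured pair shows this same change, so no step for it is known from the data. With nothing to point one way or the other, the step of a 1.1-fold lower number from compound 2 to compound 4 (0.06 log units; within the scatter) is expected to stay small, with no direction favoured beyond the scatter. Compound 4 is therefore estimated at 300 ng.h/mL, with a range from 110 ng.h/mL to 800 ng.h/mL.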

Compound 4, area under the concentration-time curve: 713 ng.h/mL
Compound 4: the middle estimate sits 2.4-fold (0.38 log units) below what was measured; the range from low to high includes it.
By their numbers in this assay, from the lowest: compound 3; then compounds 2, 1 and 4 (each within the scatter of the next, the first and the last beyond it).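

In this assay, putting cyclobutyl in place of propargyl on a saturated chain carbon, two bonds along the chain from an amide-type nitrogen and a carbonyl carbon, gives a 2.1-fold higher number from compound 2 to compound 4 (0.32 log units; beyond the scatter). For the compounds shown here, the step is modest but lies beyond the scatter, and it is the first sign from a single-place change that the group at this position can shift the number, which no earlier pair could show. Nothing measured here bears on why the number moves.

The compounds shown leave open whether the ring matters in itself, which a cyclopropyl group, a cyclopentyl group or a longer open chain at this place could test. They also leave open whether the same change would give a similar step elsewhere on the shared core.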